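The source may report more compounds than this note shows. Statements on the series, on what has been measured and on what is new or still open speak of the compounds shown alone.

Compound 1, `Cc1ccc(NC2=CC(=O)c3nc4n(c3C2=O)[C@H]2OC[C@@H](O)[C@H]2OC4)cc1`, is the starting point. In a functional assay on MGC-803 cells (Homo sapiens) for inhibition, read by sulforhodamine B assay (a higher number here means a weaker inhibitor, a lower number a stronger inhibitor), compound 1 gives 1420 nM, the lowest of the two numbers shown. Its nearest neighbour, compound 2, `O=C1C(Nc2ccc(C(F)(F)F)cc2)=CC(=O)c2c1nc1n2[C@H]2OC[C@@H](O)[C@H]2OC1`, gives 1860 nM in this assay, a gap that stays within the usual scatter of repeated measurements, so the two cannot be told apart on this evidence. Compound 3, `O=C1C(N2CCC2)=CC(=O)c2c1nc1n2[C@H]2OC[C@@H](O)[C@H]2OC1`, yields no number in this assay but only a limit, > 16000 nM (the limit of > 16000 nM in this assay, at which 1 of the 3 values shown sits).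

Compound 4, `O=C1C=C(Nc2ccccc2F)C(=O)c2c1nc1n2[C@H]2OC[C@@H](O)[C@H]2OC1`, has not yet been measured. It differs from compound 1 in a single place: 2-fluorophenyl in place of 4-methylphenyl on an amine nitrogen. Among the measured compounds shown here, no pair of measured compounds differs by exactly this exchange, so there is no measured step to lean on. What the numbers do show is that compound 1 and compound 2, each carrying a substituted phenyl on the amine nitrogen, sit within the scatter of each other, which gives no sign that a change of substituent on that ring shifts the read-out much. The step of a 1.4-fold higher number from compound 1 to compound 4 (0.15 log units; within the scatter) is therefore expected to be small and not clearly beyond the scatter, with a slight lean towards a higher number. Compound 4 is expected to give about 2000 nM in this assay, within a range from 800 nM to 5500 nM.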

Compound 4, half-maximal inhibitory concentration: 2080 nM
Compound 4: middle estimate off by 1.0-fold (0.02 log units), on the low side; low and high end bracket the measured number.
By their numbers in this assay, from the lowest: compounds 1, 2 and 4 (each within the scatter of the next). At a limit, above all of these: compound 3.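

In this assay, among the compounds shown here, putting 2-fluorophenyl in place of 4-methylphenyl on the amine nitrogen amounts to a 1.5-fold higher number from compound 1 to compound 4 (0.17 log units; within the scatter), which gives this position its only measured step and one that cannot be told apart from repeat-measurement noise. With compound 2 included, three compounds now carry a substituted phenyl on that nitrogen and sit within the scatter of one another, so a fluorine on the ring fits the same picture as the methyl and trifluoromethyl groups. Nothing measured here speaks to what lies behind so small a step.

Compound 3, which has no phenyl on that nitrogen, stands at a limit of the assay, > 16000 nM. On these data alone, whether a plain phenyl, a benzyl group or an open-chain amine such as dimethylamino on this nitrogen would give a number like those of the substituted phenyl compounds, or would fall away as compound 3 does, remains open.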